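This account rests on a few compounds, and the source may have more. Where it says the series, first, only, none or still open, it means among the compounds named here.

Measured compounds:
compound 1 `Cc1cc(CCC#N)cc(C)c1Oc1cc(Nc2ccc(C#N)cc2)c(N)cc1C(=O)N(C)C`, 38200 nM
compound 2 `CC(=O)OCc1cc(N)c(Nc2ccc(C#N)cc2)cc1Oc1c(C)cc(CCC#N)cc1C`, 44800 nM
compound 3 `Cc1cc(CCC#N)cc(C)c1Oc1cc(Nc2ccc(C#N)cc2)c(N)cc1COC(=O)C1CC1`, 42200 nM

In an ADME assay on TZM cells (Homo sapiens) for cytotoxicity, with a stated time of 1 days (a lower number here means that less compound is tolerated, a higher number that more compound is tolerated), the three numbers sit close together. Compound 3 is nearest to compound 2, with a gap of a 1.1-fold lower number from compound 2 to compound 3 (0.03 log units; within the scatter), and furthest from compound 1, with a gap of a 1.1-fold higher number from compound 1 to compound 3 (0.04 log units; within the scatter); neither gap exceeds the scatter, so the three compounds cannot be told apart on this read-out.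

Compound 4 `CNC(=O)OCc1cc(N)c(Nc2ccc(C#N)cc2)cc1Oc1c(C)cc(CCC#N)cc1C` differs from compound 3 by methylamino in place of cyclopropyl on a carbonyl carbon. Going by the values given here, the closest precedent is the step on the same carbonyl carbon, cyclopropyl in place of methyl, which gave a 1.1-fold lower number from compound 2 to compound 3 (0.03 log units; within the scatter). Replacing the whole dimethylcarbamoyl group with acetoxymethyl or ((cyclopropylcarbonyl)oxy)methyl likewise gave a 1.2-fold higher number from compound 1 to compound 2 (0.07 log units; within the scatter) and a 1.1-fold higher number from compound 1 to compound 3 (0.04 log units; within the scatter). Every change tried at this end of the core has left this assay unmoved. No data exist for a methylamino group on this carbonyl carbon, so the expectation rests only on the flatness seen so far.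

The estimated step from compound 3 to compound 4 is therefore a 1.0-fold lower number from compound 3 to compound 4 (0.00 log units; within the scatter), not beyond the scatter in either direction. Compound 4 is expected to give about 42000 nM in this assay, within 21000 nM to 84000 nM.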

Compound 4, half-maximal cytotoxic concentration: 46800 nM
Compound 4: middle estimate off by 1.1-fold (0.05 log units), on the low side; low and high end bracket the measured number.
By their numbers in this assay, from the lowest: compounds 1, 3, 2 and 4 (each within the scatter of the next).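

Going by these compounds alone, on the carbonyl carbon, methylamino is the first group here to put a nitrogen and a hydrogen-bond donor at this place, yet this assay barely registers the change: the swap for cyclopropyl gives a 1.1-fold higher number from compound 3 to compound 4 (0.04 log units; within the scatter) within the scatter, and the swap for methyl gives a 1.0-fold higher number from compound 2 to compound 4 (0.02 log units; within the scatter) also within the scatter. The ((methylcarbamoyl)oxy)methyl group now joins acetoxymethyl and ((cyclopropylcarbonyl)oxy)methyl as a replacement for dimethylcarbamoyl on an aromatic carbon, with a 1.2-fold higher number from compound 1 to compound 4 (0.09 log units; within the scatter) again within the scatter, so all four compounds remain indistinguishable on this read-out and the flatness extends from esters to a carbamate. Nothing available accounts for this flatness.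

Still open, on these data alone, is whether any group at this place can move the read-out, for example a carboxylic acid, a free hydroxymethyl in place of the whole ester or carbamate unit, or a longer chain ending in an amine on the carbonyl carbon. The rest of the shared core is constant across all four compounds, so the flatness describes this one place only and says nothing about changes to the nitrile-bearing groups elsewhere.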